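Compound 4: a shorter imidazole chain on the shared core

A few compounds are considered here, and "the series" means these few. Any claim that something is new, unique, unknown or untested is made for them only; others in the source may bear on it.

Measured in a functional assay on K562 cells (Homo sapiens) for antiproliferative activity, read by MTT assay, with a stated time of 48 h; on this read-out lower numbers stand for stronger inhibition and higher numbers for weaker inhibition:
- compound 1 `Cn1cc(C2=C(c3nn(CCCN4CCCCC4)c4ncccc34)C(=O)N(c3ccc(Cl)cc3)C2=O)c2ccccc21`: 1800 nM
- compound 2 `Cn1cc(C2=C(c3nn(CCCN4CCCCC4)c4ncccc34)C(=O)N(c3cccc4ccccc34)C2=O)c2ccccc21`: 3180 nM
- compound 3 `CN1CCN(CCCn2nc(C3=C(c4cn(C)c5ccccc45)C(=O)NC3=O)c3cccnc32)CC1`: 46700 nM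

In this assay, compound 3 has the highest number of the three at 46700 nM, beyond the scatter from both compound 1 and compound 2. The next structure, compound 4 `Cn1cc(C2=C(c3nn(CCn4ccnc4)c4ncccc34)C(=O)NC2=O)c2ccccc21`, differs from it as follows: 1H-imidazol-1-yl in place of (4-methylpiperazin-1-yl)methyl on a saturated chain carbon, two bonds along the chain from an aromatic nitrogen. This places 1H-imidazol-1-yl where (4-methylpiperazin-1-yl)methyl stood, on a saturated chain carbon, two bonds along the chain from an aromatic nitrogen.

Within the data shown here, only one measured step is available, a 1.8-fold higher number from compound 1 to compound 2 (0.25 log units; within the scatter). It lies within the scatter and concerns a different place, an amide-type nitrogen in a ring, so it says little about this chain. Among the measured compounds shown here, no measured step tests the chain change itself, and the data give no direction for it. The estimate therefore stays close to compound 3 at 46700 nM, with a wide range.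

The expected change is a 1.3-fold lower number from compound 3 to compound 4 (0.13 log units; within the scatter), which would be no shift beyond the scatter. For compound 4 the estimated value is 35000 nM, with an expected range from 10000 nM to 120000 nM.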

Compound 4, half-maximal inhibitory concentration: > 100000 nM
Compound 4: a limit, no number; the forecaster's own chance of this, stated with the estimate: 15%; middle value at least 2.8-fold (0.45 log units) away from the limit.
By their numbers in this assay, from the lowest: compounds 1 and 2 (each within the scatter of the next); then compound 3. At a limit, above all of these: compound 4.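

Compound 4 carries a limit of the assay rather than a number: the limit of > 100000 nM in this assay, at which 1 of the 4 values shown sits.

At this position, 2-(1H-imidazol-1-yl)ethyl in place of 3-(4-methylpiperazin-1-yl)propyl gives an at least 2.1-fold higher number from compound 3 to compound 4 (0.33 log units; beyond the scatter) in this assay. Among these compounds, the only earlier step concerned a different place, an amide-type nitrogen in a ring, so this is the first measured reading on the chain, and it points towards weaker inhibition.

The compounds shown leave open whether this shift goes with the imidazole ring or with the shorter chain, as the two change together here and nothing shown separates them. A 3-(1H-imidazol-1-yl)propyl chain or a 2-(4-methylpiperazin-1-yl)ethyl chain on the same core would pull these two changes apart.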